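A Methoxy Group Added to Compound 2

The source may report more compounds than this note shows. Statements on the series, on what has been measured and on what is new or still open speak of the compounds shown alone.

Among the compounds with values here, in a functional assay on THP-1 cells (Homo sapiens) for cytotoxicity, with a stated time of 72 h (on this read-out lower numbers stand for an effect already at smaller amounts and higher numbers for an effect only at larger amounts of compound), compound 1 `CC(C)=CCC/C(C)=C/Cc1c(O)cc2c(c1O)C(=O)C[C@@H](c1cc(O)cc(O)c1)O2` gives 8500 nM, the only exact number among the three compounds measured so far. Compound 2 `CC(C)=CCC/C(C)=C/Cc1c(O)cc2c(c1O)C(=O)C[C@@H](c1ccc(O)c(O)c1)O2` is reported only as a limit, < 10000 nM. Compound 3 `CC(C)=CCC/C(C)=C/Cc1cc(C2CC(=O)c3c(O)cc(O)cc3O2)c(O)cc1O` is likewise reported only as a limit, > 10000 nM. Compound 2 therefore has no exact place on this scale.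

Compound 4 `COc1cc([C@@H]2CC(=O)c3c(cc(O)c(C/C=C(\C)CCC=C(C)C)c3O)O2)cc(O)c1O` differs from compound 2 by a single change: methoxy in place of hydrogen on an aromatic carbon. Methoxy takes the place of hydrogen on an aromatic carbon, so 3,4-dihydroxyphenyl becomes 3,4-dihydroxy-5-methoxyphenyl. Within the data shown here, no measured step shows this exchange directly. The closest one, a step that the limit leaves unreadable from compound 1 to compound 2, replaces 3,5-dihydroxyphenyl with 3,4-dihydroxyphenyl, and its size cannot be carried over. Among the measured compounds shown here, the expectation therefore leans on compound 1 at 8500 nM, the one exact value available for this family, and no shift beyond the usual scatter is expected in this assay. The expected step is a step that the limit leaves unreadable from compound 2 to compound 4, and no firm direction can be assigned to it. For compound 4 the estimated value is 9000 nM, with an expected range from 4000 nM to 20000 nM.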

Compound 4, half-maximal effective concentration: < 10000 nM
Compound 4 gave a limit, no number; the forecaster's own chance of this, stated with the estimate: 40%; the middle value lies beyond the limit too.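

In this assay compound 4 is reported only as a limit, < 10000 nM. Compound 2 is likewise known only as a limit, so neither the step from compound 2 to compound 4 nor that from compound 1 to compound 4 can be read. The compounds shown leave open whether methoxy in place of hydrogen changes the read-out at all.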